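A few compounds are considered here, and "the series" means these few. Any claim that something is new, unique, unknown or untested is made for them only; others in the source may bear on it.

Three compounds have been measured in a functional assay on A498 cells (Homo sapiens) for cytotoxicity, read by sulforhodamine B assay, with a stated time of 48 h; a lower number here means a stronger inhibitor of growth, a higher number a weaker inhibitor of growth:

Compound 1, `Nc1nc(Cl)c2ncn(Cc3ccc(CCl)cc3)c2n1`, gives 21900 nM.
Compound 2, `ClCc1cccc(Cn2cnc3c(Cl)nc(Cl)nc32)c1`, gives 2390 nM.
Compound 3, `ClCc1ccc(Cn2cnc3c(Cl)nc(Cl)nc32)cc1`, gives 12000 nM.

Of the three, compound 2 gives the lowest number, and its distance from each of the other two lies beyond the usual scatter, so it is the strongest inhibitor of growth among the measured compounds. Compound 2 and compound 3 are built from the same atoms joined differently; the difference between their two cores is not broken down here.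

Compound 3 and compound 1 form a matched pair: amino in place of chloro on an aromatic carbon. This change produced a 1.8-fold higher number from compound 3 to compound 1 (0.26 log units; within the scatter), a step that stays within the scatter of repeated measurements.

Compound 4, `Nc1nc(Cl)c2ncn(Cc3cccc(CCl)c3)c2n1`, has not yet been measured in this assay. It differs from compound 2 by the same change: amino in place of chloro on an aromatic carbon. Going by the values given here, since the surroundings of the changed position read the same in both pairs, the change made from compound 2 to compound 4 is the same as the one from compound 3 to compound 1, and the only guide to its effect is that single earlier step. On that basis, compound 4 is expected to move by a 1.8-fold higher number from compound 2 to compound 4 (0.26 log units; within the scatter), a small shift in the same direction, because compound 1 sat at 21900 nM after the same change. Compound 4 is therefore estimated at 4300 nM in this assay, with a plausible range from 1700 nM to 11000 nM, the width reflecting that a single precedent within the scatter cannot fix the direction of the step with confidence.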

Compound 4, concentration for 50% growth inhibition: 25100 nM
For compound 4 the middle estimate is 5.8-fold (0.77 log units) below the measured one, and the stated range ends below it.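

The same change, amino in place of chloro on an aromatic carbon, did not carry over in size from one core to the other: in this assay it gave an 11-fold higher number from compound 2 to compound 4 (1.02 log units; beyond the scatter), and set beside the earlier step the two do not agree: the same change on two cores in this assay, a 1.8-fold higher number (0.26 log units; within the scatter) from compound 3 to compound 1 and an 11-fold higher number (1.02 log units; beyond the scatter) from compound 2 to compound 4, 5.8-fold (0.76 log units) apart, beyond the scatter of two such steps

Only the step on the core of compound 2 lies beyond the scatter, so a clear weakening of growth inhibition with this change is shown for that core alone, and the earlier pair cannot be taken as a guide to its size on another core. What this does not show is the reason for the gap, since the two cores are built from the same atoms joined differently and two pairs cannot separate that difference from anything else, nor say how the change would behave on any further core.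

The compounds shown leave open whether another group on the carbon between two ring nitrogen atoms, such as a methylamino or a methoxy group, would follow amino or chloro on either core. They also leave open whether the gap between the two steps would survive if the chloromethyl group gave way to a hydroxymethyl group or a longer chain.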